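A few compounds are considered here, and "the series" means these few. Any claim that something is new, unique, unknown or untested is made for them only; others in the source may bear on it.

Compound 3 `CCCCOc1c(OC)c(OC)cc2c1C(=O)[C@]1(OC)C=C[C@H]2N(C(=O)OC)N1C(=O)OC` in an ADME assay on KB cells (Homo sapiens) for cytotoxicity (on this read-out higher numbers stand for an effect only at larger amounts of compound and lower numbers for an effect already at smaller amounts), is reported only as a limit, > 300 ug/mL, which is the limit of > 300 ug/mL in this assay, at which 1 of the 3 values shown sits. Compound 1 `COC(=O)N1[C@@H]2C=C[C@@](OC)(C(=O)c3c2cc(OC)c(OC)c3OCc2ccccc2F)N1C(=O)OC` gives 137 ug/mL in this assay. The two differ by 2-fluorophenyl in place of propyl on a saturated chain carbon bound to an oxygen on an aromatic ring, and the step is an at least 2.1-fold lower number from compound 3 to compound 1 (0.34 log units; beyond the scatter). Compound 2 `CCCCOc1c(OC)c(OC)cc2c1C(=O)[C@]1(OC)C=C[C@H]2N(C(=O)OCC(C)C)N1C(=O)OCC(C)C` gives 22.1 ug/mL in this assay; how the cores of compound 2 and compound 3 differ is not broken down here. Compound 4 `COc1cc2c(c(OCc3ccccc3F)c1OC)C(=O)[C@]1(OC)C=C[C@H]2N(C(=O)OCC(C)C)N1C(=O)OCC(C)C` is not yet measured in this assay. It differs from compound 2 by 2-fluorophenyl in place of propyl on a saturated chain carbon bound to an oxygen on an aromatic ring, the same change at the same place as between compound 3 and compound 1. The step expected from compound 2 to compound 4 is a 2.5-fold lower number from compound 2 to compound 4 (0.39 log units; beyond the scatter), set beside an at least 2.1-fold lower number from compound 3 to compound 1 (0.34 log units; beyond the scatter), which is known only as a lower bound because one end sits at the limit of > 300 ug/mL in this assay, at which 1 of the 3 values shown sits. Compound 4 is therefore estimated at 9 ug/mL, between 3 ug/mL and 25 ug/mL.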

Compound 4, concentration for half-maximal effect: 109 ug/mL
Compound 4: middle estimate off by 12-fold (1.08 log units), on the low side; the measured number lies above the stated range.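

The change from propyl to 2-fluorophenyl gives a 4.9-fold higher number from compound 2 to compound 4 (0.69 log units; beyond the scatter) in this assay. Set beside the earlier step, the direction reverses, so this change does not carry over from one core to the other: the same change on two cores in this assay, an at least 2.1-fold lower number (0.34 log units; beyond the scatter) from compound 3 to compound 1 and a 4.9-fold higher number (0.69 log units; beyond the scatter) from compound 2 to compound 4, at least 10-fold (1.03 log units) apart, beyond the scatter of two such steps Compound 3 stands only as a limit, > 300 ug/mL, so the earlier step has a bound rather than an exact size, and these two pairs do not show what drives the reversal or how the change behaves on any other core.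

The compounds shown leave open how the two cores respond when an amine or a carboxylic acid enters at the same place in place of propyl. From the compounds shown here alone, whether a longer chain there follows the step of either core also remains open.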